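Aryl urea piperazines as TRPV1 inhibitors: a trifluoromethyl swap

A few compounds are considered here, and "the series" means these few. Any claim that something is new, unique, unknown or untested is made for them only; others in the source may bear on it.

Four ureas built on a piperazine share the same right-hand aryl urea, while the left-hand heteroaryl differs. Compound 1 `Cc1ccc(N2CCN(C(=O)Nc3ccc(C(C)C)cc3)CC2)nn1` and compound 2 `Cc1ccc(N2CCN(C(=O)Nc3ccc(C(F)(F)F)cc3)CC2)nn1` carry one core; compound 3 `CC(C)c1ccc(NC(=O)N2CCN(c3nncc4ccccc34)CC2)cc1` and the still unmeasured compound 4 `O=C(Nc1ccc(C(F)(F)F)cc1)N1CCN(c2nncc3ccccc23)CC1` carry another. The difference between the two cores is not broken down here.

In an assay on HEK293 cells for inhibition of transient receptor potential cation channel subfamily V member 1 (Homo sapiens), read by FLIPR (a lower number here means a stronger inhibitor, a higher number a weaker inhibitor), compound 1 gives > 10000 nM, which is a limit of the assay rather than a number. Compound 2 likewise gives > 10000 nM, again a limit. Compound 3 also gives > 10000 nM, once more a limit.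

From compound 1 to compound 2 the change is trifluoromethyl in place of isopropyl on an aromatic carbon, and the step is a step that the two limits leave unreadable from compound 1 to compound 2. The same change, (trifluoromethyl in place of isopropyl on an aromatic carbon), leads from compound 3 to compound 4. Among the measured compounds shown here, every value so far sits at the limit of > 10000 nM in this assay, at which 3 of the 3 values shown sit, so the change has not been seen to move anything.

The step from compound 3 to compound 4 is expected to be a step that the limit leaves unreadable from compound 3 to compound 4, resting on (the limit of > 10000 nM in this assay, at which 3 of the 3 values shown sit). Compound 4 is therefore expected to give 15000 nM, most likely reported only as a limit.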

Compound 4, half-maximal inhibitory concentration: > 10000 nM
Compound 4: only a limit was reported; the forecaster's own chance of this, stated with the estimate: 85%; the middle value lies beyond the limit too.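

Among the compounds shown here, compound 4 adds no step that can be read: from compound 3 to compound 4, as from compound 1 to compound 2, both ends are limits of the assay, so the size of the change stays unknown. All four compounds sit together: the limit of > 10000 nM in this assay, at which 4 of the 4 values shown sit.

The compounds shown leave open whether trifluoromethyl in place of isopropyl changes inhibition at all.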